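The source may hold more compounds than are shown below. What is called first, only, known or untested is meant among the compounds shown, and "the series" means these compounds.

Measured compounds:
- compound 1, `COc1ccc(C(=O)N[C@H]2CCC[C@H](NC(=O)c3cccc(Cl)c3)C2)cc1`: 674 nM
- compound 2, `O=C(N[C@@H]1CCC[C@@H](NC(=O)c2ccccn2)C1)c1cccc(Cl)c1`: 205 nM
- compound 3, `Cc1cccc(C(=O)N[C@H]2CCC[C@H](NC(=O)c3cccc(Cl)c3)C2)n1`: 582 nM

In an assay on HEK293 cells for displacement of a labelled ligand from metabotropic glutamate receptor 5 (Homo sapiens), read by scintillation counting, with a stated time of 60 min (a higher number here means a weaker inhibitor, a lower number a stronger inhibitor), compound 3 gives 582 nM, second highest of the three numbers. Compound 1 lies nearest, with the step of a 1.2-fold lower number from compound 1 to compound 3 (0.06 log units; within the scatter). Compound 2 sits furthest from compound 3, beyond the scatter.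

Compound 4, `O=C(N[C@H]1CCC[C@H](NC(=O)c2cccc(Cl)c2)C1)c1ccc(F)cc1`, has not yet been measured in this assay. The change is 4-fluorophenyl in place of 6-methylpyridin-2-yl on a carbonyl carbon. Going by the values given here, the only measured step at that carbonyl carbon is a 1.2-fold lower number from compound 1 to compound 3 (0.06 log units; within the scatter), an aryl swap that stayed within the scatter, so a change of the aryl group there may again move little. Among the compounds with values here, no measured pair covers a fluorophenyl group. The expected step is a 1.1-fold lower number from compound 3 to compound 4 (0.02 log units; within the scatter), with the number estimated close to those of compound 1 and compound 3. Compound 4 is therefore expected to give about 550 nM, within a range of 200 nM to 1500 nM.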

Compound 4, inhibition constant: 492 nM
Estimate against measurement, compound 4: 1.1-fold (0.05 log units) above, within the range that was stated.
By their numbers in this assay, from the lowest: compound 2; then compounds 4, 3 and 1 (each within the scatter of the next).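

At this carbonyl carbon, 4-fluorophenyl in place of 6-methylpyridin-2-yl gives a 1.2-fold lower number from compound 3 to compound 4 (0.07 log units; within the scatter) in this assay, so an aromatic ring of carbon only reads the same here as one holding a hetero atom. Fluoro in place of methoxy on the aromatic carbon gives a 1.4-fold lower number from compound 1 to compound 4 (0.14 log units; within the scatter), so the three aryl groups on this side all lie within the scatter of one another. No data on hand explain this flat response.

Still open, from the compounds shown here alone, is whether the position stays as flat with a carboxylic acid or an amine on the ring, or with a longer chain in place of the ring.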